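Substituent on the ring amine nitrogen: working notes

The source may report more compounds than this note shows. Statements on the series, on what has been measured and on what is new or still open speak of the compounds shown alone.

Measured so far:
compound 1 `CN1CCN(C(=O)Cn2c(=O)c3c(ncn3C)n(C)c2=O)CC1` — 8.6%
compound 2 `Cn1cnc2c1c(=O)n(CC(=O)N1CCN(c3ccccc3)CC1)c(=O)n2C` — 4.6%
compound 3 `C#CCN1CCN(C(=O)Cn2c(=O)c3c(ncn3C)n(C)c2=O)CC1` — 14.1%

All three share one core and differ only in the group on an amine nitrogen in a six-membered non-aromatic ring with 2 nitrogen. In a functional assay on MGC-803 cells (Homo sapiens) for inhibition, read by MTT assay, with a stated time of 48 h, tested at 20 uM (on this read-out lower numbers stand for less inhibition and higher numbers for more inhibition at the one concentration tested (going by the name of the read-out)), compound 3 gives 14.1%, the highest of the three numbers shown, yet the steps to both others fall within the scatter: a number 5.5 percentage points higher from compound 1 to compound 3 (within the scatter) and a number 9.5 percentage points higher from compound 2 to compound 3 (within the scatter). Compound 1 and compound 2 are likewise within scatter of one another, a number 4 percentage points lower from compound 1 to compound 2 (within the scatter). Across the measured set, no group on this nitrogen stands apart.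

Compound 4 `C=CC(=O)N1CCN(C(=O)Cn2c(=O)c3c(ncn3C)n(C)c2=O)CC1` is not yet measured. Its change from compound 3 is vinylcarbonyl in place of propargyl on an amine nitrogen in a ring. Among the compounds with values here, the steps that bear on it are those that altered the same nitrogen's substituent, a number 9.5 percentage points higher from compound 2 to compound 3 (within the scatter) and a number 5.5 percentage points higher from compound 1 to compound 3 (within the scatter), each within the scatter. Three different groups on this nitrogen have left the read-out flat, and no measured step beyond the scatter exists to build on. Going by these compounds, the vinylcarbonyl is untested, so the expectation rests on little, and a step no larger than the scatter is expected in either direction, a number 2.1 percentage points lower from compound 3 to compound 4 (within the scatter). For compound 4 the estimate is 12%, with a range from 2% to 24%.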

Compound 4, a percentage reported as inhibition, at one concentration (the size of the read-out at that concentration, not a potency): 1.3%
Estimate against measurement, compound 4: 10.7 percentage points above, and the stated range ends above it.
By their numbers in this assay, from the lowest: compounds 4, 2, 1 and 3 (each within the scatter of the next, the first and the last beyond it).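

Substituent on the ring amine nitrogen: reading of compound 4

In this assay, within the data shown here, this nitrogen no longer looks entirely flat: with vinylcarbonyl in place of propargyl, a number 12.8 percentage points lower from compound 3 to compound 4 (beyond the scatter), the first step at this position to pass the scatter, though only a modest one. Among these compounds, the other two changes at the same nitrogen do not separate in the same way, with a number 3.3 percentage points lower from compound 2 to compound 4 (within the scatter) and a number 7.3 percentage points lower from compound 1 to compound 4 (within the scatter), so the new separation rests on the single pair of compound 3 and compound 4 and does not set vinylcarbonyl apart from phenyl or methyl. Nothing available accounts for the difference between the propargyl and vinylcarbonyl groups.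

The compounds shown leave open whether the lower number for compound 4 goes with the carbonyl or with the vinyl part of the new group, and an acetyl group on this nitrogen would help separate the two. They also leave open whether the triple bond of propargyl matters to the number for compound 3, a question that a saturated propyl chain at the same nitrogen would address.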